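A few compounds are considered here, and "the series" means these few. Any claim that something is new, unique, unknown or untested is made for them only; others in the source may bear on it.

In an ADME assay on HEK293 cells (Homo sapiens) for cytotoxicity, with a stated time of 72 h (on this read-out higher numbers stand for an effect only at larger amounts of compound and lower numbers for an effect already at smaller amounts), compound 3 `Cc1cc(NC(=O)Nc2ccc(F)cc2)c2ccccc2n1` gives only a limit of the assay, > 25000 nM. Compound 2 `Cc1cc(NC(=O)Nc2ccc(F)c(F)c2)c2ccccc2n1` likewise reaches only the limit > 25000 nM there. Compound 1 `Cc1cc(NC(=O)Nc2cccc([N+](=O)[O-])c2)c2ccccc2n1` also shows only the limit > 25000 nM. Among the measured compounds shown here, all three measured values therefore sit at the limit of > 25000 nM in this assay, at which 3 of the 3 values shown sit, and the one measured step, a step that the two limits leave unreadable from compound 2 to compound 3, cannot be read. Compound 4 `Cc1cc(NC(=O)Nc2ccc(N)cc2)c2ccccc2n1` differs from compound 3 by amino in place of fluoro on an aromatic carbon. For the measured compounds named here, no measured step bears on this change, and the three values offer no spread to draw on. Compound 4 is therefore expected to remain at the same limit, so that the expected step that the limit leaves unreadable from compound 3 to compound 4 is likely to stay unreadable. The cytotoxicity of compound 4 is estimated at 50000 nM, expected between 20000 nM and 200000 nM.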

Compound 4, half-maximal effective concentration: > 25000 nM
Compound 4: a limit, no number; the forecaster's own chance of this, stated with the estimate: 85%; the middle value is on the limit's open side.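

No step can be read between compound 3 and compound 4, because both give only a limit of the assay: the limit of > 25000 nM in this assay, at which 4 of the 4 values shown sit.

The compounds shown leave open whether any of them truly differs from another in this assay.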